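Replacing the nitro group in compound 1 with dimethylamino

The source may report more compounds than this note shows. Statements on the series, on what has been measured and on what is new or still open speak of the compounds shown alone.

Measured so far:
compound 1 `CN1CCC[C@H]1[C@@H]1COc2ccc([N+](=O)[O-])cc2O1` gives 4500 nM in an assay on membranes from HEK293 cells for displacement of a labelled ligand from Neuronal acetylcholine receptor; alpha3/beta4 (Homo sapiens), with a stated time of 5 min; on this read-out higher numbers stand for weaker inhibition and lower numbers for stronger inhibition;
compound 2 `CN1CCC[C@H]1[C@H]1COc2ccc([N+](=O)[O-])cc2O1` gives 2100 nM in this assay;
compound 3 `CN1CCC[C@H]1[C@H]1COc2c(cccc2-c2ccccc2)O1` gives 5300 nM in this assay.

Compound 1 stands second highest of the three numbers; its nearest neighbour is compound 3, which lies within the scatter, and its furthest is compound 2, reached by a 2.1-fold lower number from compound 1 to compound 2 (0.33 log units; beyond the scatter), a step that rests only on (the fact that compounds 1 and 2 differ only in the configuration as drawn).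

Compound 4 `CN(C)c1ccc2c(c1)O[C@H]([C@@H]1CCCN1C)CO2` differs from compound 1 by dimethylamino in place of nitro on an aromatic carbon. For the measured compounds named here, none of the measured steps touches this position or this kind of exchange; the step from compound 1 to compound 2 concerns configuration alone, and compound 3 carries a different substitution pattern altogether. There is therefore no measured basis for a directed change, and compound 4 is expected to remain close to compound 1, with a 1.1-fold lower number from compound 1 to compound 4 (0.05 log units; within the scatter) not beyond the scatter.

Compound 4 is estimated at 4000 nM, within a range from 1300 nM to 12000 nM.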

Compound 4, inhibition constant: 2200 nM
Beside the measured number, compound 4's estimate is 1.8-fold (0.26 log units) above it; the measured number falls inside the stated range.
By their numbers in this assay, from the lowest: compounds 2 and 4 (each within the scatter of the next); then compounds 1 and 3 (each within the scatter of the next).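

In this assay, for the compounds shown here, the aromatic carbon that carries nitro in compound 1 tolerates exchange, and dimethylamino there brings a 2.0-fold lower number from compound 1 to compound 4 (0.31 log units; beyond the scatter) as the first measured step at this position. Nitro is therefore not required at this carbon to hold the number at the level of compound 1, and a group of the same heavy-atom size but without oxygen does modestly better. No available evidence bears on why this exchange lowers the number.

The compounds shown leave open whether dimethylamino would bring a similar step on the configuration drawn in compound 2. They also leave open how a primary amine, a methoxy group or a carboxylic acid on this same aromatic carbon would compare with nitro and dimethylamino.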